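The source may report more compounds than this note shows. Statements on the series, on what has been measured and on what is new or still open speak of the compounds shown alone.

Compound 1 `COc1cc(NC(=O)Nc2cc(Nc3cc(F)ccc3OC)ncn2)cc(OC)c1` gives 42.1% in a functional assay on NCI-H1581 cells (Homo sapiens) for inhibition, read by MTT assay, with a stated time of 48 h, tested at 10 uM; a lower number here means less inhibition, a higher number more inhibition at the concentration tested (going by the name of the read-out).
Compound 2 `COc1cc(NC(=O)Nc2cc(Nc3cc(C(F)(F)F)ccc3OC)ncn2)cc(OC)c1` gives 67.1% in this assay.

Of these two numbers compound 1 stands lowest; its nearest neighbour is compound 2, reached by a number 25 percentage points higher from compound 1 to compound 2 (beyond the scatter). Compound 3 `COc1cc(NC(=O)Nc2cc(Nc3ccc(OC)c(C)c3)ncn2)cc(OC)c1` has not yet been measured in this assay. It differs from compound 1 in one place: 4-methoxy-3-methylphenyl in place of 5-fluoro-2-methoxyphenyl on a nitrogen on an aromatic ring. Going by the values given here, the only measured step concerns a trifluoromethyl in place of fluoro on an aromatic carbon, a different change on the same part of the molecule, so it does not bear directly on the move from compound 1 to compound 3; it shows only that altering this aryl group can shift the number by a modest amount. Among the compounds with values here, with no step of matching kind, no direction is expected beyond the scatter, though a modest shift either way remains possible. Compound 3 is therefore expected to give about 45% in this assay, within 25% to 65%, an expected step of a number 2.9 percentage points higher from compound 1 to compound 3 (within the scatter).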

Compound 3, a percentage reported as inhibition, at one concentration (the size of the read-out at that concentration, not a potency): 19.7%
For compound 3 the middle estimate is 25.3 percentage points above the measured one; measured number outside the range, below it.
By their numbers in this assay, from the lowest: compound 3; then compound 1; then compound 2.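

In this assay, going by these compounds alone, the aryl group on the nitrogen can also take the number down: there is a number 22.4 percentage points lower from compound 1 to compound 3 (beyond the scatter), whereas the only earlier step on this part of the molecule went up. The swap of 5-fluoro-2-methoxyphenyl for 4-methoxy-3-methylphenyl leaves the counts of heavy atoms, hydrogen-bond donors and hydrogen-bond acceptors unchanged, so those counts do not separate the two groups. Nothing available here accounts for the drop.

The compounds shown leave open which part of this swap carries the step: the loss of fluoro, the arrival of methyl or the different place of the methoxy. They also leave open how an aryl group carrying an amine or a carboxylic acid would read in this assay.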